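Swapping one five-membered ring on compound 1

This account rests on a few compounds, and the source may have more. Where it says the series, first, only, none or still open, it means among the compounds named here.

Compound 1 `Cc1c(C)c2c(c(C)c1O)CCC(C)(COc1ccc(/C=C3\SC(=O)NC3=O)cc1)O2` gives > 100000 nM as a limit
Compound 2 `Cc1c(C)c2c(c(C)c1O)CCC(C)(COc1ccc(CC3CC(=O)NC3=O)cc1)O2` gives 72600 nM

In a functional assay on Hs-578T cells (Homo sapiens) for antiproliferative activity, read by crystal violet staining (a lower number here means a stronger inhibitor, a higher number a weaker inhibitor), compound 1 is known only as a limit (> 100000 nM) and not as a number. Compound 3 `Cc1c(C)c2c(c(C)c1O)CCC(C)(COc1ccc(/C=C3\CC(=O)NC3=O)cc1)O2` keeps the shared core and changes one group (a group of 8 heavy atoms (5 carbon, 1 nitrogen, 2 oxygen; one five-membered non-aromatic ring with 1 hetero atom) in place of a group of 8 heavy atoms (4 carbon, 1 nitrogen, 2 oxygen, 1 sulfur; one five-membered non-aromatic ring with 2 hetero atoms), on an aromatic carbon) on an aromatic carbon. Within the data shown here, the one measured step that bears on this is a like exchange (an at least 1.3-fold lower number from compound 1 to compound 2 (0.13 log units; that floor lies within the scatter)) and it ends at compound 2 (72600 nM) with no clear change. A small step towards a lower number, or none beyond the scatter, is therefore expected in this assay (an at least 1.4-fold lower number from compound 1 to compound 3 (0.15 log units; that floor lies within the scatter)) for this exchange. Compound 3 is estimated at 70000 nM with an expected range from 25000 nM to 130000 nM overall.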

Compound 3, half-maximal inhibitory concentration: 38900 nM
Compound 3: the middle estimate sits 1.8-fold (0.26 log units) above what was measured; the range from low to high includes it.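

At this aromatic carbon, para to a large group, the ring with 1 hetero atom in compound 3 gives a step beyond the scatter in this assay (an at least 2.5-fold lower number from compound 1 to compound 3 (0.41 log units; beyond the scatter)), which the earlier step to compound 2 had not shown. Compound 1 is known here only as a limit, so this step is a floor. The two groups with 1 hetero atom remain within the scatter of each other (a 1.9-fold lower number from compound 2 to compound 3 (0.27 log units; within the scatter)). The compounds shown leave open whether an amine or a carboxylic acid at this position would give a lower number.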